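Piperazine in Place of a Cyclobutyl Amide

A few compounds are considered here, and "the series" means these few. Any claim that something is new, unique, unknown or untested is made for them only; others in the source may bear on it.

Compound 1 `Nc1sc(-c2ccc(Cl)cc2)c(-c2ccc(Cl)cc2)c1C(=O)NC1CCC1` is measured in a functional assay on A549 cells (Homo sapiens) for inhibition, read by sulforhodamine B assay, with a stated time of 72 h (a lower number here means a stronger inhibitor, a higher number a weaker inhibitor), at 12500 nM, the higher of the two numbers available here. Compound 2 `CC(=O)Nc1sc(-c2ccc(Cl)cc2)c(-c2ccc(Cl)cc2)c1C(=O)N1CCCCC1` gives 6010 nM in this assay, a gap from compound 1 that lies beyond the usual scatter. Compound 3 `CS(=O)(=O)Nc1sc(-c2ccc(Cl)cc2)c(-c2ccc(Cl)cc2)c1C(=O)NC1CC1` has no result reported in this assay, its entry reading "not determined" (no result reported). Compound 4 `Nc1sc(-c2ccc(Cl)cc2)c(-c2ccc(Cl)cc2)c1C(=O)N1CCNCC1` keeps the core of compound 1 and alters only the group on the carbonyl carbon: piperazin-1-yl in place of cyclobutylamino on a carbonyl carbon. Among the compounds with values here, no measured pair shows this exact change, and compound 2 differs from compound 1 in more than one place, so no guide to direction exists. Compound 4 is therefore expected to sit close, with a step of a 1.0-fold lower number from compound 1 to compound 4 (0.02 log units; within the scatter) estimated to stay within the scatter. The estimate for compound 4 in this assay is 12000 nM, ranging from 4000 nM to 40000 nM.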

Compound 4, half-maximal inhibitory concentration: 1020 nM
For compound 4 the middle estimate is 12-fold (1.07 log units) above the measured one; the whole stated range lies above it.
By their numbers in this assay, from the lowest: compound 4; then compound 2; then compound 1.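

In this assay the group on the carbonyl carbon proves to be a strong lever: piperazin-1-yl in place of cyclobutylamino gives a 12-fold lower number from compound 1 to compound 4 (1.09 log units; beyond the scatter) on an otherwise unchanged core. Within the data shown here, this is the first single-place change, and it shows that this position does not merely tolerate a larger ring carrying a second nitrogen. Nothing given here accounts for the size of this step.

The compounds shown do not separate the contribution of ring size from that of the second ring nitrogen. Morpholin-4-yl or 4-methylpiperazin-1-yl on the same carbonyl carbon remains an open comparison.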